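The source may hold more compounds than are shown below. What is called first, only, known or untested is meant among the compounds shown, and "the series" means these compounds.

Measured in a functional assay on NCI-H23 cells (Homo sapiens) for inhibition, read by sulforhodamine B assay, with a stated time of 48 h; on this read-out higher numbers stand for weaker inhibition of growth and lower numbers for stronger inhibition of growth:
compound 1 `O=C(Nc1cccc(-n2cc(-c3ccncc3)c(-c3ccc(Cl)c(O)c3)n2)c1)Nc1cccc(C(F)(F)F)c1`: 1900 nM
compound 2 `O=C(Nc1cccc(-n2cc(-c3ccncc3)c(-c3ccc(Cl)c(O)c3)n2)c1)Nc1ccc(Cl)c(Cl)c1`: 1220 nM
compound 3 `COc1cc(-c2nn(-c3cccc(NC(=O)Nc4ccc(Cl)c(C(F)(F)F)c4)c3)cc2-c2ccncc2)ccc1Cl`: 1310 nM

Compound 3 stands second highest of the three numbers in this assay, with compound 2 and compound 1 on either side and both within the scatter of it. Going by the values given here, the only measured step, a 1.6-fold lower number from compound 1 to compound 2 (0.19 log units; within the scatter), alters the aryl on the amide-type nitrogen and lies within the scatter.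

Compound 4 `O=C(Nc1cccc(-n2cc(-c3ccncc3)c(-c3ccc(Cl)c(O)c3)n2)c1)Nc1ccc(Cl)c(C(F)(F)F)c1` differs from compound 3 by hydrogen in place of methyl on an oxygen on an aromatic ring. Among the compounds with values here, no measured step covers this change; compound 1 and compound 2, which carry the hydroxy, and compound 3, which carries the methoxy, all give numbers within the scatter of one another. Compound 4 is therefore expected to show no step beyond the scatter, a 1.0-fold lower number from compound 3 to compound 4 (0.00 log units; within the scatter). The estimate for compound 4 in this assay is 1300 nM, range 550 nM to 3100 nM.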

Compound 4, concentration for 50% growth inhibition: 951 nM
The estimate for compound 4 lay 1.4-fold (0.14 log units) above the measured number, and the stated range covers the measured number.
By their numbers in this assay, from the lowest: compounds 4, 2, 3 and 1 (each within the scatter of the next).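

In this assay, methoxy to hydroxy on the 4-chloro-3-methoxyphenyl group gives a 1.4-fold lower number from compound 3 to compound 4 (0.14 log units; within the scatter), so either group is accommodated at this oxygen as far as this read-out can resolve. On the other aryl, trifluoromethyl in place of chloro (a 1.3-fold lower number from compound 2 to compound 4 (0.11 log units; within the scatter)) and chloro in place of hydrogen (a 2.0-fold lower number from compound 1 to compound 4 (0.30 log units; within the scatter)) also fail to separate the compounds. Nothing available bears on the reason for these results.

Open, from the compounds shown here alone, is whether an ethoxy group or a longer chain on this oxygen, or an amine in its place, would give a step beyond the scatter.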